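The source may hold more compounds than are shown below. What is called first, only, known or untested is meant among the compounds shown, and "the series" means these compounds.

This set turns on one small swap made twice. Compound 1 `COc1ccc(-c2ccnc(Nc3ccc(Cl)cc3Cl)n2)cc1` and compound 2 `Cc1ccc(-c2ccnc(Nc3ccc(Cl)cc3Cl)n2)cc1` share a core and differ in a single spot, where (methoxy in place of methyl on an aromatic carbon). In a functional assay on MCF7 cells (Homo sapiens) for antiproliferative activity, read by MTT assay (on this read-out higher numbers stand for weaker inhibition and lower numbers for stronger inhibition), compound 1 gives 4170 nM. For compound 2 the assay reports no number, only a limit, > 1000000 nM. The step between the two, an at least 230-fold lower number from compound 2 to compound 1 (2.37 log units; beyond the scatter), is therefore a large one, and its size rests on (the limit of > 1000000 nM in this assay, at which 1 of the 3 values shown sits).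

Compound 3 `Cc1cccc(Nc2nccc(-c3ccc(Cl)cc3Cl)n2)c1` is built from the same atoms as compound 2, joined differently; the difference between the two cores is not broken down here. In this assay compound 3 gives 249000 nM, the higher of the two plain numbers and well apart from compound 1.

Compound 4 `COc1cccc(Nc2nccc(-c3ccc(Cl)cc3Cl)n2)c1` has not yet been measured in this assay. It stands to compound 3 as compound 1 stands to compound 2: here too (methoxy in place of methyl on an aromatic carbon). It is the same kind of change, not the same one, since in the earlier pair the group sat para to a large group, while here it sits meta to a large group.

Going by the values given here, the step expected for compound 4 is estimated as an 8.3-fold lower number from compound 3 to compound 4 (0.92 log units; beyond the scatter), a more modest drop than before, because an at least 230-fold lower number from compound 2 to compound 1 (2.37 log units; beyond the scatter) is the only guide and its size is itself bounded by a limit. Compound 4 is estimated at 30000 nM, with a likely range from 3000 nM to 200000 nM.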

Compound 4, half-maximal inhibitory concentration: 192000 nM
Compound 4: middle estimate off by 6.4-fold (0.81 log units), on the low side, within the range that was stated.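

On the core of compound 3, putting methoxy in place of methyl gives a 1.3-fold lower number from compound 3 to compound 4 (0.11 log units; within the scatter) in this assay, so on this core the swap leaves the read-out within the normal spread of repeated measurements. The large step seen on the first core therefore did not carry over to the second, and a change that looks decisive on one core cannot be assumed to do the same on a related one: the same change on two cores in this assay, an at least 230-fold lower number (2.37 log units; beyond the scatter) from compound 2 to compound 1 and a 1.3-fold lower number (0.11 log units; within the scatter) from compound 3 to compound 4, at least 180-fold (2.26 log units) apart, beyond the scatter of two such steps

This does not show why the two steps differ or how large the first one truly is, since the two pairs differ both in their core and in where the group sits, and the first step rests on a limit rather than a plain number: the limit of > 1000000 nM in this assay, at which 1 of the 4 values shown sits.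

The compounds shown leave open whether the sharp difference belongs to the core or to the position of the group, as no pair here changes one of these while holding the other fixed. They also leave open how other groups in the same place, such as an amine, a carboxylic acid or a longer chain like ethoxy, would behave on either core.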